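The source may report more compounds than this note shows. Statements on the series, on what has been measured and on what is new or still open speak of the compounds shown alone.

Working notes on the series.

The shared core carries an ester and a ring-borne substituent that varies across the set. Compound 1 `COc1cc(OC)cc(C(=O)OC2CCN(C)CC2)c1` is the highest of the measured compounds, giving 1.53 in a functional assay on the whole organism with Mus musculus as the target; on this read-out higher numbers stand for higher potency (the scale is a negative logarithm) and lower numbers for lower potency. Compound 2 `Cc1ccc(C(=O)OC2CCN(C)CC2)cc1` gives 1.17, and compound 3 `CN1CCC(OC(=O)c2ccc(Cl)cc2)CC1` gives 1.11. Compound 3 thus sits within the scatter of compound 2, while the gap to compound 1 lies beyond the scatter.

For the measured compounds named here, the single measured step that touches the same ring position is the one from compound 2 to compound 3: a number 0.06 log units lower from compound 2 to compound 3 (within the scatter), a change of chloro in place of methyl on an aromatic carbon.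

Compound 4 `CN1CCC(OC(=O)c2ccc(C(C)(C)C)cc2)CC1` differs from compound 3 as follows: tert-butyl in place of chloro on an aromatic carbon. Going by the values given here, the only comparable step, a number 0.06 log units lower from compound 2 to compound 3 (within the scatter), shows that exchanging one small group for another at this position left the read-out unchanged within the scatter, and nothing measured speaks for a tert-butyl group in particular. The step from compound 3 to compound 4 is therefore expected to be small, a number 0.01 log units lower from compound 3 to compound 4 (within the scatter), with no direction favoured. Compound 4 is estimated at 1.1, with a range from 0.7 to 1.5.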

Compound 4, logarithm of the reciprocal of the active concentration, log(1/C): 1.13
Compound 4: the middle estimate sits 0.03 log units below what was measured; the range from low to high includes it.
By their numbers in this assay, from the lowest: compounds 3, 4 and 2 (each within the scatter of the next); then compound 1.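

At this position, the change from chloro to tert-butyl goes from 1 heavy atom to 4, yet the read-out stays flat, with a number 0.02 log units higher from compound 3 to compound 4 (within the scatter) and a number 0.04 log units lower from compound 2 to compound 4 (within the scatter) as the two new steps. The earlier compounds shown here showed only that methyl and chloro could be exchanged within the scatter; compounds 2, 3 and 4 now show the same for a much larger carbon group. Among these three compounds, the heavy-atom count of the substituent therefore does not separate the numbers, and nothing at hand bears on the reason for this.

Still open, from the compounds shown here alone, is whether a group of another kind at this position, such as an amine or a carboxylic acid, would stay with these three compounds. How far the tolerance seen here extends beyond carbon groups and chloro also remains unresolved.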